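Dichlorophenyl piperazine amides: minimum effective dose series

This account rests on a few compounds, and the source may have more. Where it says the series, first, only, none or still open, it means among the compounds named here.

Measured so far:
compound 1 `CC1CC(=O)N(CC(=O)N2CCN(c3ccccc3)CC2)C1=O` — 300 mg/kg
compound 2 `CC1CC(=O)N(CC(=O)N2CCN(c3cccc(Cl)c3Cl)CC2)C1=O` — 100 mg/kg

In a functional assay on the whole organism (strain CD1) with Mus musculus as the target, with a stated time of 4 h (on this read-out lower numbers stand for an effect already at smaller amounts and higher numbers for an effect only at larger amounts of compound), compound 1 gives 300 mg/kg. In this assay, going by the values given here, compound 2 gives 100 mg/kg, the lowest of the two numbers; the only step recorded is a 3.0-fold lower number from compound 1 to compound 2 (0.48 log units; beyond the scatter), and it lies beyond the scatter.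

Compound 3 `CC1CC(=O)N(CC(=O)N2CCN(c3ccc(Cl)c(Cl)c3)CC2)C1=O` has not been measured. It differs from compound 2 as follows: 3,4-dichlorophenyl in place of 2,3-dichlorophenyl on an amine nitrogen in a ring.

Among the compounds with values here, no measured step bears directly on this change. Within the data shown here, the one step available concerns the addition of two chlorines to the phenyl, not their placement, and the place itself is the same ring nitrogen in both compounds. The two dichlorophenyl groups carry the same atoms joined differently, so the change gives no basis to expect a step beyond the scatter in this assay in either direction.

Compound 3 is therefore expected to stay near compound 2, with an expected step of no change at the digits printed from compound 2 to compound 3 (within the scatter). The estimate for compound 3 in this assay is 100 mg/kg, with a range from 50 mg/kg to 300 mg/kg.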

Compound 3, minimum effective dose: 100 mg/kg
Beside the measured number, compound 3's estimate shows no gap at the digits printed; low and high end bracket the measured number.
By their numbers in this assay, from the lowest: compounds 2 and 3 (each within the scatter of the next); then compound 1.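

In this assay, the shift from 2,3-dichlorophenyl to 3,4-dichlorophenyl on the amine nitrogen in the ring gives no change at the digits printed from compound 2 to compound 3 (within the scatter), so this pair shows no sensitivity of the read-out to where the two chlorines sit. The step away from plain phenyl also holds with the new arrangement, at a 3.0-fold lower number from compound 1 to compound 3 (0.48 log units; beyond the scatter), matching a 3.0-fold lower number from compound 1 to compound 2 (0.48 log units; beyond the scatter), so the lower number is no longer tied to the 2,3-dichlorophenyl group alone. No supporting measurement bears on either step.

Going by these compounds alone, the series so far has only phenyl and two dichlorophenyl groups at this position, so it remains open whether a single chlorine, a methoxy or a trifluoromethyl group on the phenyl would give a number like those of compound 2 and compound 3. Also open, from the compounds shown here alone, is how the read-out responds to changes elsewhere on the shared core, such as an ethyl group or a hydrogen in place of the methyl group.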